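This account rests on a few compounds, and the source may have more. Where it says the series, first, only, none or still open, it means among the compounds named here.

Compound 1 `CCNc1cc(-c2ccc(NC(=O)Nc3ccc(OC)cc3)cc2C)ccn1`: 25800 nM
Compound 2 `CCNc1cc(-c2ccc(NC(=O)Nc3cccc(Cl)c3)cc2C(F)(F)F)ccn1`: 13300 nM

In a functional assay on BT-483 cells (Homo sapiens) for cytotoxicity, read by MTT assay, with a stated time of 24 h (a lower number here means a stronger inhibitor, a higher number a weaker inhibitor), compound 2 gives 13300 nM and compound 1 gives 25800 nM. These two values lie within the usual scatter of each other, so compound 2 stands level with compound 1 and neither can be ranked.

Compound 3 `CCNc1cc(-c2ccc(NC(=O)Nc3ccc(OC)cc3)cc2C(F)(F)F)ccn1` keeps the rest of compound 2 and changes one group: 4-methoxyphenyl in place of 3-chlorophenyl on an amide-type nitrogen. Among the measured compounds shown here, no measured pair shows what this swap does on its own. However, compound 1 also carries 4-methoxyphenyl on an amide-type nitrogen and gives 25800 nM, so a large change seems unlikely. In this assay, a step no larger than the scatter is expected, if anything towards a higher number. The expected change is a 1.4-fold higher number from compound 2 to compound 3 (0.13 log units; within the scatter). For compound 3 the estimated value is 18000 nM, with an expected range of 8000 nM to 40000 nM.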

Compound 3, half-maximal inhibitory concentration: 17600 nM
Compound 3: the middle estimate sits 1.0-fold (0.01 log units) above what was measured; the measured number falls inside the stated range.
By their numbers in this assay, from the lowest: compounds 2, 3 and 1 (each within the scatter of the next).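

In this assay, among the compounds shown here, the swap to 4-methoxyphenyl in place of 3-chlorophenyl on the amide-type nitrogen gives a 1.3-fold higher number from compound 2 to compound 3 (0.12 log units; within the scatter) and so leaves the two compounds level, which is the first direct reading of this change with the rest of the molecule held fixed. The second one-place comparison, trifluoromethyl in place of methyl on an aromatic carbon, gives a 1.5-fold lower number from compound 1 to compound 3 (0.17 log units; within the scatter) and also leaves its pair level, so neither change can be ranked as better or worse here. Nothing measured here explains why these compounds stand level.

As far as these compounds go, all three compounds lie within the scatter of one another, so it remains unknown whether any change at these places can move the number by a readable amount. An amine or a carboxylic acid on that outer ring would test this more sharply than the two groups compared so far.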